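Swapping the methoxyphenyl arm of compound 1 for a bicyclic group

A few compounds are considered here, and "the series" means these few. Any claim that something is new, unique, unknown or untested is made for them only; others in the source may bear on it.

Compound 1 `COc1ccc(-c2nc(-c3ccccc3)c(-c3ccc4c(c3)NC(=O)CO4)[nH]2)cc1` carries a 4-methoxyphenyl group on the aromatic carbon of its five-membered ring that sits between two ring nitrogen atoms. In a functional assay on DLD-1 cells (Homo sapiens) for cytotoxicity, read by colorimetric assay and MTT assay, with a stated time of 3 days, tested at 20 uM (on this read-out lower numbers stand for a stronger effect and higher numbers for a weaker effect at the one concentration tested), compound 1 gives 19.1%, the lowest of the three numbers shown and therefore the strongest effect. Compound 2 `COc1ccc(-n2cc(-c3ccccc3)c(-c3ccc4c(c3)NC(=O)CO4)n2)cc1` gives 35.6%, and compound 3 `O=C1COc2ccc(-c3nn(-c4ccc(Cl)cc4)cc3-c3ccccc3)cc2N1` gives 47.1%. Going by the values given here, the one change studied directly, chloro in place of methoxy on an aromatic carbon, moves the read-out a number 11.5 percentage points higher from compound 2 to compound 3 (beyond the scatter), a weakening.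

Compound 4 `O=C1COc2ccc(-c3[nH]c(-c4c[nH]c5ncccc45)nc3-c3ccccc3)cc2N1` differs from compound 1 in this way: a group of 9 heavy atoms (7 carbon, 2 nitrogen; one five-membered aromatic ring with 1 hetero atom, one six-membered aromatic ring with 1 hetero atom) in place of a group of 8 heavy atoms (7 carbon, 1 oxygen; one six-membered aromatic ring of carbon only), on an aromatic carbon. Among the compounds with values here, no measured step covers such a swap of an aryl group for a two-ring heteroaromatic group; the step from compound 2 to compound 3 shows only that a change at this arm can shift the number by a modest amount. Compound 4 is therefore expected to land near compound 1, with a modest weakening as the likelier direction, a step of a number 10.9 percentage points higher from compound 1 to compound 4 (beyond the scatter). The estimate for compound 4 is 30%, within a range from 12% to 55%.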

Compound 4, a percentage reported as activity, at one concentration (the size of the read-out at that concentration, not a potency): 53.5%
Compound 4: the middle estimate sits 23.5 percentage points below what was measured; the measured number falls inside the stated range.
By their numbers in this assay, from the lowest: compound 1; then compound 2; then compounds 3 and 4 (each within the scatter of the next).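

In this assay, the aromatic carbon between two ring nitrogen atoms proves sensitive to what it carries: the two-ring heteroaromatic group in place of 4-methoxyphenyl gives a large weakening, with a number 34.4 percentage points higher from compound 1 to compound 4 (beyond the scatter). The change in heavy atoms is small, 9 in place of 8, so a similar atom count does not preserve the effect at this position. No evidence is available on why the effect falls.

The compounds shown do not separate the contributions of the second ring, the ring nitrogen atoms and the added hydrogen-bond donor. A plain phenyl or a 4-aminophenyl group on this carbon of the core of compound 1 would help show which of these features matters.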